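Adding a chlorinated benzylidene arm to the parent thiosemicarbazide

The source may report more compounds than this note shows. Statements on the series, on what has been measured and on what is new or still open speak of the compounds shown alone.

Compound 1, `CC1=CC[C@@H]([C@@](C)(O)CCCC(C)(C)NC(=S)NN)CC1`, is the parent of this small set. In a functional assay on K562 cells (Homo sapiens) for cytotoxicity, read by sulforhodamine B assay (on this read-out lower numbers stand for stronger inhibition of growth and higher numbers for weaker inhibition of growth), compound 1 gives 20 nM, the lowest number of the three measured compounds. Two related compounds carry an aromatic arm on the same nitrogen: compound 2, `CC1=CC[C@@H]([C@@](C)(O)CCCC(C)(C)NC(=S)N/N=C\c2ccc(C)cc2)CC1`, gives 140 nM, and compound 3, `COc1ccc(/C=N\NC(=S)NC(C)(C)CCC[C@](C)(O)[C@@H]2CC=C(C)CC2)cc1`, gives 220 nM. Both steps away from the parent weaken growth inhibition, as a 7.0-fold higher number from compound 1 to compound 2 (0.85 log units; beyond the scatter) and an 11-fold higher number from compound 1 to compound 3 (1.04 log units; beyond the scatter) show. Between the two aromatic arms themselves the gap, a 1.6-fold higher number from compound 2 to compound 3 (0.20 log units; within the scatter), is small.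

Compound 4, `CC1=CC[C@@H]([C@@](C)(O)CCCC(C)(C)NC(=S)N/N=C\c2cccc(Cl)c2)CC1`, has not yet been measured. It differs from compound 1 by a group of 9 heavy atoms (7 carbon, 1 nitrogen, 1 chlorine; one six-membered aromatic ring of carbon only) in place of one nitrogen atom, on an amide-type nitrogen. This is the same kind of change as the steps to compound 2 and compound 3, so a weakening of similar size is expected in this assay, with no reason in the data for the chlorine to behave differently from the methyl or methoxy. Compound 4 is therefore estimated at 160 nM, with a range from 70 nM to 360 nM. This corresponds to an expected step of an 8.0-fold higher number from compound 1 to compound 4 (0.90 log units; beyond the scatter).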

Compound 4, concentration for 50% growth inhibition: 30 nM
The estimate for compound 4 lay 5.3-fold (0.73 log units) above the measured number; the measured number lies below the stated range.
By their numbers in this assay, from the lowest: compounds 1 and 4 (each within the scatter of the next); then compounds 2 and 3 (each within the scatter of the next).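

An aromatic arm on this amide-type nitrogen need not cost growth inhibition in this assay: the arm bearing 3-chlorophenyl gives a step within the scatter (a 1.5-fold higher number from compound 1 to compound 4 (0.18 log units; within the scatter)), whereas both earlier arms gave steps beyond it. What the ring carries therefore matters at this position, as 3-chlorophenyl gives clearly lower numbers than either 4-methoxyphenyl (a 7.3-fold lower number from compound 3 to compound 4 (0.87 log units; beyond the scatter)) or 4-methylphenyl (a 4.7-fold lower number from compound 2 to compound 4 (0.67 log units; beyond the scatter)). No measurement at hand accounts for this difference.

Open, as far as these compounds go, is whether the chlorine itself or its place on the ring sets the outcome, a question that a 4-chlorophenyl arm and a 3-methylphenyl arm would help to separate. Also open, from the compounds shown here alone, is whether the ring must be aromatic at all, which a cyclohexyl group in its place would test.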